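The source may hold more compounds than are shown below. What is called first, only, known or untested is meant among the compounds shown, and "the series" means these compounds.

Measured so far:
compound 1 `CSCC[C@@H](N)C(=O)NCc1ccccc1`, giving 75 mg/kg in a functional assay on the whole organism (strain NMRI) with Mus musculus as the target, in the maximal electroshock model, with a stated time of 30 min; on this read-out higher numbers stand for an effect only at larger amounts of compound and lower numbers for an effect already at smaller amounts
compound 2 `CCC[C@H](N)C(=O)NCc1ccccc1`, giving > 37 mg/kg in this assay

Among the measured compounds shown here, compound 1 stands as the only real number in this assay; the other value is a limit. For compound 2 the value > 37 mg/kg in this assay is a limit of the assay and not a number, as the limit of > 37 mg/kg in this assay, at which 1 of the 2 values shown sits, records. Compound 3 `CCCC[C@@H](N)C(=O)NCc1ccccc1` differs from compound 1 by ethyl in place of methylsulfanyl on a saturated chain carbon, three bonds along the chain from an amine nitrogen and a carbonyl carbon. For the measured compounds named here, with no measured step between two numbers to lean on, the step of a 1.2-fold lower number from compound 1 to compound 3 (0.06 log units; within the scatter) that the estimate means is expected to be no larger than the usual scatter, in no clear direction. Compound 3 is therefore expected to give about 65 mg/kg in this assay, within 30 mg/kg to 150 mg/kg.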

Compound 3, dose for half-maximal effect: 23 mg/kg
Compound 3: middle estimate off by 2.8-fold (0.45 log units), on the high side; the whole stated range lies above it.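

At this saturated chain carbon the choice of group matters: in this assay, ethyl in place of methylsulfanyl brings a 3.3-fold lower number from compound 1 to compound 3 (0.51 log units; beyond the scatter) and so an effect at smaller doses. The sulfur atom is therefore not needed for activity in this model, since compound 3 has none. Nothing shown gives a reason for this step.

Compound 2 stands at > 37 mg/kg which is a limit and not a number, so its chain cannot yet be compared. Also open, going by these compounds, is how a longer chain, or an ether oxygen in place of the sulfur, would fare here.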